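The source may hold more compounds than are shown below. What is called first, only, known or untested is meant among the compounds shown, and "the series" means these compounds.

Working notes on the series in a functional assay on CHO cells with sphingosine 1-phosphate receptor 4 (Homo sapiens) as the target, read by GTPgammaS binding; a higher number here means that more compound is needed for the effect, a lower number that less compound is needed.

Compound 3 `COc1cc(-c2nc(-c3ccc(CCC(=O)O)cc3C)no2)ccc1OC(C)C` is the reference for this step. In this assay compound 3 gives only a limit, > 10000 nM. Compound 1 `Cc1cc(CCC(=O)O)ccc1-c1noc(-c2ccc(OC(C)C)c(F)c2)n1` carries fluoro on the same aromatic carbon where compound 3 carries methoxy. In this assay compound 1 also returns only a limit, > 10000 nM. Compound 2 `Cc1cc(CCC(=O)O)ccc1-c1noc(-c2ccc(OC(C)C)c(Cl)c2)n1` carries chloro on that carbon. In this assay compound 2 likewise returns only a limit, > 10000 nM. All three stand at the limit of > 10000 nM in this assay, at which 3 of the 3 values shown sit, and none of the steps among them can be sized: a step that the two limits leave unreadable from compound 1 to compound 2, a step that the two limits leave unreadable from compound 1 to compound 3, a step that the two limits leave unreadable from compound 2 to compound 3.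

Compound 4 `Cc1cc(CCC(=O)O)ccc1-c1noc(-c2ccc(OC(C)C)c(C#N)c2)n1` differs from compound 3 in cyano in place of methoxy on an aromatic carbon. The measured steps that bear on this change all concern the same carbon and are all unreadable; fluoro, chloro and methoxy there have yielded no number in this assay. Compound 4 is therefore expected to stay at the limit as well, the step that the limit leaves unreadable from compound 3 to compound 4 being estimated as not readable. The estimate for compound 4 in this assay is 20000 nM, with a range from 5000 nM to 100000 nM.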

Compound 4, half-maximal effective concentration: > 10000 nM
Compound 4: a limit, no number; the forecaster's own chance of this, stated with the estimate: 85%; the middle value lies beyond the limit too.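

In this assay, for the compounds shown here, compound 4 gives > 10000 nM, again a limit and not a number, so no step from compound 1, compound 2 or compound 3 to compound 4 can be read. The compounds shown leave open whether fluoro, chloro, methoxy and cyano on that aromatic carbon differ at all in this assay, with every value at one limit: the limit of > 10000 nM in this assay, at which 4 of the 4 values shown sit.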